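Anilino for 4-methoxyphenyl on a carbonyl carbon

The source may hold more compounds than are shown below. What is called first, only, known or untested is meant among the compounds shown, and "the series" means these compounds.

In a functional assay on OCI-Ly3 cells (Homo sapiens) for inhibition, read by CellTiter-Glo, with stated times of 48 h and 96 h (on this read-out lower numbers stand for stronger inhibition of growth and higher numbers for weaker inhibition of growth), compound 1 `CC(C)[C@@H](C(=O)N1CCC[C@H]1C(=O)N[C@@H](CCCNC(=N)N)C(=O)CF)N(C)C(=O)OCc1ccccc1` gives > 20000 nM, which is a limit of the assay and not a number. Among the measured compounds shown here, compound 2 `COc1ccc(C(=O)N[C@H](C(=O)N2CCC[C@H]2C(=O)N[C@@H](CCCNC(=N)N)C(=O)CF)C(C)C)cc1` gives 1670 nM, the only actual number so far. Compound 3 `CC(C)[C@H](NC(=O)Nc1ccccc1)C(=O)N1CCC[C@H]1C(=O)N[C@@H](CCCNC(=N)N)C(=O)CF` differs from compound 2 in one place: anilino in place of 4-methoxyphenyl on a carbonyl carbon. For the measured compounds named here, the one measured step, an at least 11-fold lower number from compound 1 to compound 2 (1.07 log units; beyond the scatter), shows that this end of the molecule can matter greatly, but it is a different change and rests on a limit. An aromatic ring stays in place, so only a small shift is expected in this assay. The expected step is a 1.5-fold higher number from compound 2 to compound 3 (0.18 log units; within the scatter), towards weaker inhibition and not beyond the scatter. For compound 3 the estimated value is 2500 nM, with an expected range from 700 nM to 10000 nM.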

Compound 3, concentration for 50% growth inhibition: 1520 nM
The estimate for compound 3 lay 1.6-fold (0.22 log units) above the measured number; the measured number falls inside the stated range.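

In this assay, the step is a 1.1-fold lower number from compound 2 to compound 3 (0.04 log units; within the scatter), so on this carbonyl carbon anilino and 4-methoxyphenyl cannot be told apart, even though a hydrogen-bond donor replaces a hydrogen-bond acceptor. Compound 1 gives > 20000 nM, which is a limit of the assay and not a number. The second new step is an at least 13-fold lower number from compound 1 to compound 3 (1.11 log units; beyond the scatter), and like the earlier step from compound 1 it gives only a minimum size: the limit of > 20000 nM in this assay, at which 1 of the 3 values shown sits.

Still open, on these data alone, is whether an aromatic ring is needed here at all, as a cyclohexyl group or a simple amine on this carbonyl carbon would show. Also open, as far as these compounds go, is how a carboxylic acid on the phenyl ring would fare.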